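Removing the Amino Link Between Compound 3 and Compound 4

The compounds below may be only part of what the source reports. "The series", "measured", "known", "first", "only" and "open" are said of these compounds alone.

Three measured compounds share one core and differ only in the ring carried by an amide-type nitrogen. In a functional assay on SK-OV-3 cells (Homo sapiens) for inhibition, read by sulforhodamine B assay, with a stated time of 48 h, tested at 10 uM (on this read-out higher numbers stand for a weaker effect at the one concentration tested and lower numbers for a stronger effect), compound 1 `COc1cc(Cl)cc(-c2nn(-c3cccc(NC(=O)Nc4ccc(Cl)c(C(F)(F)F)c4)c3)cc2-c2ccncc2)c1` gives 12%. Compound 2 `COc1cc(Cl)cc(-c2nn(-c3cccc(NC(=O)Nc4ccc(Cl)c(Cl)c4)c3)cc2-c2ccncc2)c1` gives 14.2%, and compound 3 `COc1cc(Cl)cc(-c2nn(-c3cccc(NC(=O)Nc4cccc(C(F)(F)F)c4)c3)cc2-c2ccncc2)c1` gives 14.2%. The steps among them are small: a number 2.2 percentage points higher from compound 1 to compound 2 (within the scatter), a number 2.2 percentage points higher from compound 1 to compound 3 (within the scatter), and no change at the digits printed from compound 2 to compound 3 (within the scatter). Compound 3 therefore sits level with compound 2, the two together holding the highest of the three numbers, with compound 1 the furthest away by a margin that still lies within the scatter.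

Compound 4 `COc1cc(Cl)cc(-c2nn(-c3cccc(NC(=O)c4cccc(C(F)(F)F)c4)c3)cc2-c2ccncc2)c1` is built from compound 3 by a different kind of change: 3-(trifluoromethyl)phenyl in place of (3-(trifluoromethyl)phenyl)amino on a carbonyl carbon. Within the data shown here, none of the measured steps touches this carbonyl carbon; each of them swaps substituents on the outer ring and each stayed within the scatter, so they give no direct guidance on the loss of a hydrogen-bond donor here. A modest move toward a weaker effect is expected, as a step of a number 7.8 percentage points higher from compound 3 to compound 4 (within the scatter). Compound 4 is estimated at 22%, within a range from 8% to 50%.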

Compound 4, a percentage reported as activity, at one concentration (the size of the read-out at that concentration, not a potency): 81.6%
Beside the measured number, compound 4's estimate is 59.6 percentage points below it; the measured number lies above the stated range.
By their numbers in this assay, from the lowest: compounds 1, 2 and 3 (each within the scatter of the next); then compound 4.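

In this assay the link at the carbonyl carbon matters far more than the substituents on the outer ring, which moved the number only within the scatter: replacing (3-(trifluoromethyl)phenyl)amino with 3-(trifluoromethyl)phenyl gives a number 67.4 percentage points higher from compound 3 to compound 4 (beyond the scatter), a much weaker effect. The comparisons with the two other compounds agree, at a number 67.4 percentage points higher from compound 2 to compound 4 (beyond the scatter) and a number 69.6 percentage points higher from compound 1 to compound 4 (beyond the scatter), although each of these also changes the outer ring. Nothing available bears on why the effect weakens at this position.

The compounds shown leave open whether the amide hydrogen or the amino link as a whole is what counts, a question that a methylamino or methylene group in the same place could address. From the compounds shown here alone, it also remains open whether the outer-ring substituents would matter once the amino link is gone.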